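A few compounds are considered here, and "the series" means these few. Any claim that something is new, unique, unknown or untested is made for them only; others in the source may bear on it.

In a toxicity assay on MCF7 cells (Homo sapiens) for cytotoxicity, read by MTT assay, with a stated time of 3 h (a higher number here means a weaker inhibitor, a lower number a stronger inhibitor), compound 1 (`COc1ccc(C2=[N+]3C(=Nc4c(-c5ccccc5)c5c(n4[B-]3(F)F)-c3ccc(OC)cc3CC5)C(c3ccccc3)=C2Br)cc1`) gives > 50000 nM, which is a limit of the assay and not a number. Compound 2 (`COc1ccc2c(c1)CCc1c(-c3ccccc3)c3n(c1-2)[B-](F)(F)[N+]1=C(c2ccc(C)cc2)C(Br)=C(c2ccccc2)C1=N3`) also gives only a limit, > 50000 nM. Where compound 2 stands is therefore known only through (the limit of > 50000 nM in this assay, at which 2 of the 2 values shown sit).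

Compound 3 (`COc1ccc2c(c1)CCc1c(-c3ccccc3)c3n(c1-2)[B-](F)(F)[N+]1=C(c2ccc(C)s2)C(Br)=C(c2ccccc2)C1=N3`) differs from compound 2 in one group, with the shared core unchanged: 5-methylthiophen-2-yl in place of 4-methylphenyl on a carbon with a double bond to nitrogen. Here 5-methylthiophen-2-yl replaces 4-methylphenyl on a carbon with a double bond to nitrogen.

For the measured compounds named here, only one measured step bears on this change: a step that the two limits leave unreadable from compound 1 to compound 2. That step put methyl in place of methoxy on an aromatic carbon, and its size cannot be read, so it offers no number to carry over. What it does show is that neither compound gave a measurable value. No step beyond the usual scatter is therefore expected in this assay, in either direction, and another limit is the likeliest report.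

The estimated change is a step that the limit leaves unreadable from compound 2 to compound 3. For compound 3 the expected value is 60000 nM, with an estimated range from 25000 nM to 150000 nM.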

Compound 3, half-maximal inhibitory concentration: > 50000 nM
Compound 3: no number, only a limit; the forecaster's own chance of this, stated with the estimate: 85%; the middle value is on the limit's open side.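

In this assay compound 3 gives > 50000 nM, which is a limit and not a number. The steps linking compound 1, compound 2 and compound 3 cannot be read. These three compounds leave open what number each would give, and whether exchanging their groups changes the result in this assay at all.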